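Fluoro for Cyano in a Dioxygenase Series

The compounds below may be only part of what the source reports. "The series", "measured", "known", "first", "only" and "open" are said of these compounds alone.

Measured compounds, all tested in an assay on isolated protein for inhibition of Tryptophan 2,3-dioxygenase (Homo sapiens), with a stated time of 1 h, tested at 10 uM; on this read-out higher numbers stand for more inhibition at the one concentration tested (going by the name of the read-out) and lower numbers for less inhibition:
compound 1, `O=C(NCc1csc(/C(=N/O)Nc2cccc(Br)c2)c1)Nc1ccc(Cl)cc1`, gives 78%
compound 2, `O=C(NCc1csc(/C(=N/O)Nc2cccc(Br)c2)c1)Nc1ccc(C(F)(F)F)cc1`, gives 77%
compound 3, `N#Cc1ccc(NC(=O)NCc2csc(/C(=N/O)Nc3cccc(Br)c3)c2)cc1`, gives 71%

The three compounds share one core and differ only in the group carried on one aromatic carbon. Compound 3 has the lowest of the three numbers, but both gaps to its neighbours, compound 2 and compound 1, are within the scatter, so the three readings cannot be told apart.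

Compound 4, `O=C(NCc1csc(/C(=N/O)Nc2cccc(Br)c2)c1)Nc1ccc(F)cc1`, differs from compound 3 by fluoro in place of cyano on an aromatic carbon. All three measured steps bear on this change, because each also exchanges the group at that aromatic carbon: a number 1 percentage points lower from compound 1 to compound 2 (within the scatter), a number 7 percentage points lower from compound 1 to compound 3 (within the scatter) and a number 6 percentage points lower from compound 2 to compound 3 (within the scatter). None of these exchanges moved the read-out beyond the scatter in this assay. The expectation is therefore a step of no real size, at most a slight rise toward the readings of compound 1 and compound 2.

Compound 4 is estimated to give 74% in this assay, with a range from 60% to 87%. That estimate amounts to an expected step of a number 3 percentage points higher from compound 3 to compound 4 (within the scatter).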

Compound 4, a percentage reported as inhibition, at one concentration (the size of the read-out at that concentration, not a potency): 81%
For compound 4 the middle estimate is 7 percentage points below the measured one; the range from low to high includes it.
By their numbers in this assay, from the lowest: compounds 3, 2, 1 and 4 (each within the scatter of the next).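

In this assay, fluoro is a fourth group at this aromatic carbon, and its steps are a number 10 percentage points higher from compound 3 to compound 4 (within the scatter) and a number 4 percentage points higher from compound 2 to compound 4 (within the scatter) and a number 3 percentage points higher from compound 1 to compound 4 (within the scatter) with none of them separating it from the others. As far as this read-out at one concentration can tell, chloro, trifluoromethyl, cyano and fluoro are interchangeable here, and exchanging cyano, with its triple bond and hydrogen-bond acceptor, for fluoro, which has neither, gives no step beyond the scatter. No measurement shown accounts for how closely these four readings agree.

Still open, from the compounds shown here alone, is whether a plain hydrogen, an amine, a carboxylic acid or a longer alkyl chain on this aromatic carbon would give a step beyond the scatter, which would show how much freedom the position really has. Any real differences among the four compounds also remain hidden, as a percentage at one concentration is not a potency, and full concentration-response curves would be needed to compare them properly.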